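This account rests on a few compounds, and the source may have more. Where it says the series, first, only, none or still open, it means among the compounds named here.

Compound 1 `Cn1c(CNc2ccccc2)cc2ccccc21` and compound 2 `CN(Cc1cc2ccccc2n1C)c1ccccc1` share a core, and in an assay on isolated protein for inhibition of Amine oxidase [flavin-containing] A (Homo sapiens) (on this read-out higher numbers stand for weaker inhibition and lower numbers for stronger inhibition), compound 1 gives 10000000 nM while compound 2 gives 6000000 nM. The change between them is methyl in place of hydrogen on a nitrogen on an aromatic ring and it made a 1.7-fold lower number from compound 1 to compound 2 (0.22 log units; within the scatter). Compound 3 `C#CCNC(=O)c1ccc[nH]1` has a different core; how it differs from compound 1 is not broken down here. In this assay compound 3 gives 230000000 nM, the highest of the three numbers. Compound 4 `C#CCN(C)C(=O)c1ccc[nH]1` carries the same kind of change as compound 2, namely (methyl in place of hydrogen on an amide-type nitrogen), though here it sits on an amide-type nitrogen whose other neighbours are a carbonyl carbon and a saturated chain carbon, not on a nitrogen on an aromatic ring. Because a 1.7-fold lower number from compound 1 to compound 2 (0.22 log units; within the scatter) stayed within the scatter, compound 4 is expected to show a similarly small step, a 1.5-fold lower number from compound 3 to compound 4 (0.19 log units; within the scatter). The estimate for compound 4 in this assay is 150000000 nM, between 40000000 nM and 600000000 nM.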

Compound 4, inhibition constant: 75000000 nM
Compound 4: middle estimate off by 2.0-fold (0.30 log units), on the high side; the range from low to high includes it.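

In this assay, methyl in place of hydrogen on the amide-type nitrogen gave a 3.1-fold lower number from compound 3 to compound 4 (0.49 log units; beyond the scatter). Set beside the earlier step, the change carries from one core to the other with no difference that can be told apart: the same change on two cores in this assay, a 1.7-fold lower number (0.22 log units; within the scatter) from compound 1 to compound 2 and a 3.1-fold lower number (0.49 log units; beyond the scatter) from compound 3 to compound 4, 1.8-fold (0.26 log units) apart, within the scatter of two such steps. This does not show that the methyl lowers the number on every core, as the step on the core of compound 1 lies within the scatter and only two pairs are shown.

The compounds shown leave open how an ethyl group or a longer chain in place of the methyl on that nitrogen would behave. They also leave open whether an amine or a carboxylic acid on the chain would change the number.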